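Trading a Thiophene Carbonyl for an Acetyl Group

This account rests on a few compounds, and the source may have more. Where it says the series, first, only, none or still open, it means among the compounds named here.

Of the compounds shown here, three of a shared core have been tested in a functional assay on MCF7 cells (Homo sapiens) for cytotoxicity, read by fluorescence, with a stated time of 72 h; on this read-out lower numbers stand for stronger inhibition and higher numbers for weaker inhibition. Compound 1 `Nc1nn(C(=O)c2cccs2)c(N)c1/N=N/c1ccc(O)cc1` carries a (thiophen-2-yl)carbonyl group on an aromatic nitrogen of that core. In this assay compound 1 gives only a limit, > 25000 nM, so no number is known for it, and it sits at the limit of > 25000 nM in this assay, at which 1 of the 3 values shown sits. Compound 2 `Nc1n[nH]c(N)c1/N=N/c1cc[n+]([O-])cc1` also returns only a limit, > 100000 nM, which is the limit of > 100000 nM in this assay, at which 1 of the 3 values shown sits. Compound 3 `Cn1nc(N)c(/N=N/c2ccncc2)c1N`, which has a methyl directly on the core instead of a carbonyl group, gives 37700 nM. All three readings point to weak inhibition, and compound 1 stands among them with nothing more than a limit.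

Compound 4 `CC(=O)n1nc(N)c(/N=N/c2ccc(O)cc2)c1N` has not been measured. It differs from compound 1 in a single place: methyl in place of thiophen-2-yl on a carbonyl carbon. The five-membered ring on the carbonyl carbon is removed and an acetyl group remains. For the measured compounds named here, no measured pair shows the effect of this change. Because compound 1 gives only > 25000 nM and compound 3 gives 37700 nM, the expected change, a step that the limit leaves unreadable from compound 1 to compound 4, is nothing beyond the usual scatter. Compound 4 is therefore expected to come in around 40000 nM, between 15000 nM and 150000 nM, quite possibly as a limit only.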

Compound 4, half-maximal inhibitory concentration: 44900 nM
Estimate against measurement, compound 4: 1.1-fold (0.05 log units) below; the range from low to high includes it.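

The step from compound 1 to compound 4 cannot be read: compound 1 gives only a limit, > 25000 nM, and no number to compare. The compounds shown leave open how far, if at all, methyl in place of thiophen-2-yl on a carbonyl carbon shifts the reading in this assay.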